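Chloro for Methyl on the Outer Phenoxy Ring

The compounds below may be only part of what the source reports. "The series", "measured", "known", "first", "only" and "open" are said of these compounds alone.

Three compounds have been measured in a functional assay on cells for agonist activity at Free fatty acid receptor 1 (Homo sapiens), read by FLIPR and calcium flux, with a stated time of 100 s; on this read-out lower numbers stand for an effect already at smaller amounts and higher numbers for an effect only at larger amounts of compound:

Compound 1, `Cc1ccc(Oc2ccc(N3CCC[C@H]3CC(=O)O)cc2)cc1`, gives 490 nM.
Compound 2, `O=C(O)C[C@@H]1CCCN1c1ccc(Oc2ccc(Cl)cc2)cc1`, gives 290 nM.
Compound 3, `Cc1cccc(Oc2ccc(N3C[C@@H](C(F)(F)F)C[C@H]3CC(=O)O)cc2)c1C`, gives 110 nM.

Compound 3 stands lowest of the three; its nearest neighbour is compound 2, and compound 1 lies furthest. The difference between the core of compound 3 and that of compound 1 is not broken down here.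

Compound 2 differs from compound 1 by chloro in place of methyl on an aromatic carbon, and this change gave a 1.7-fold lower number from compound 1 to compound 2 (0.23 log units; within the scatter).

Compound 4, `Cc1c(Cl)cccc1Oc1ccc(N2C[C@@H](C(F)(F)F)C[C@H]2CC(=O)O)cc1`, is not yet measured. It differs from compound 3 by chloro in place of methyl on an aromatic carbon. Among the measured compounds shown here, this is the same kind of change as the one from compound 1 to compound 2, but the surroundings differ: in compound 2 the chloro sits para to a large group, whereas in compound 4 it sits ortho to a methyl group and meta to a large group.

Because the earlier step was a 1.7-fold lower number from compound 1 to compound 2 (0.23 log units; within the scatter), a step of similar size is expected here, a 1.4-fold lower number from compound 3 to compound 4 (0.14 log units; within the scatter). Compound 4 is therefore estimated at 80 nM, with a plausible range from 35 nM to 220 nM.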

Compound 4, half-maximal effective concentration: 82 nM
The estimate for compound 4 lay 1.0-fold (0.01 log units) below the measured number; the measured number falls inside the stated range.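

In this assay, the swap from 2,3-dimethylphenoxy to 3-chloro-2-methylphenoxy gave a 1.3-fold lower number from compound 3 to compound 4 (0.13 log units; within the scatter). Set beside the earlier case of chloro in place of methyl, the two steps do not differ by more than repeated measurements would: the same change on two cores in this assay, a 1.7-fold lower number (0.23 log units; within the scatter) from compound 1 to compound 2 and a 1.3-fold lower number (0.13 log units; within the scatter) from compound 3 to compound 4, 1.3-fold (0.10 log units) apart, within the scatter of two such steps. On these two cores, then, the swap carried over with no visible difference, but neither step stands clear of the scatter, so the pair does not show that chloro truly lowers the number relative to methyl, and two cores say nothing certain about a third.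

Still open, on these data alone, is whether a different group at this place, such as a nitrile or a methoxy group, would shift the number by more than the scatter. Also open, as far as these compounds go, is whether chloro in place of methyl would behave the same way elsewhere on this ring, where its surroundings would differ.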